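Allyl in Place of Phenyl on an Aromatic Nitrogen

The source may report more compounds than this note shows. Statements on the series, on what has been measured and on what is new or still open speak of the compounds shown alone.

Measured so far in a functional assay on the whole organism (strain albino) for inhibition, with Rattus norvegicus as the target, read by paw edema, with a stated time of 4 h, at a dose of 0.28 mmol/kg by the oral route; on this read-out lower numbers stand for less inhibition and higher numbers for more inhibition at the one dose given (going by the name of the read-out):
compound 1 `COc1ccc(-c2nnc(SC/C(=N/O)c3ccccc3)n2-c2ccccc2)cc1`: 80%
compound 2 `O/N=C(/CSc1nnc(-c2ccccc2)n1-c1ccccc1)c1ccccc1`: 79%

Going by the values given here, compound 1 has the highest of the two numbers, yet its one neighbour is close: a number 1 percentage points lower from compound 1 to compound 2 (within the scatter), so the two are not told apart. Compound 3 `C=CCn1c(SC/C(=N/O)c2ccccc2)nnc1-c1ccc(OC)cc1` is not yet measured in this assay. It differs from compound 1 in one place: allyl in place of phenyl on an aromatic nitrogen. Among the compounds with values here, the only measured step, from compound 1 to compound 2, changes a group on a different ring, so no measured step bears on this change; the data give no guide to what an allyl on the aromatic nitrogen does. Since compound 1 gives 80% and compound 2 gives 79%, the shared core with either aryl group sits high, and the estimate for compound 3 is expected to stay near that level but with wider uncertainty: a number 10 percentage points lower from compound 1 to compound 3 (within the scatter), with compound 3 expected to give 70%, between 50% and 88%.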

Compound 3, a percentage reported as inhibition, in the whole organism at one dose (the size of the read-out at that dose, not a potency): 76%
For compound 3 the middle estimate is 6 percentage points below the measured one, and the stated range covers the measured number.
By their numbers in this assay, from the lowest: compounds 3, 2 and 1 (each within the scatter of the next).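

In this assay putting allyl in place of phenyl on the aromatic nitrogen gives a number 4 percentage points lower from compound 1 to compound 3 (within the scatter) and so does not tell the two compounds apart. Compound 3 thus shows that this position can carry a small open chain with one double bond and no ring, in place of a six-membered aromatic ring, while the number stays at the high level of compound 1, something the earlier step on the methoxy group could not show. Nothing available explains why this exchange leaves the read-out within the scatter.

As far as these compounds go, whether the nitrogen would accept other groups as well, such as a plain methyl, a longer butyl chain or a chain ending in an amine, remains open. A reading at a single dose also leaves open how the potencies of these compounds compare.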